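The source may hold more compounds than are shown below. What is called first, only, known or untested is meant among the compounds shown, and "the series" means these compounds.

Compound 2 `O=C(Nc1ccc(Cl)c(-c2nnc3c(Cl)cccn23)c1)c1c(F)cccc1Cl` stands at the edge of what a functional assay on MDA-MB-231 cells (Homo sapiens) for antiproliferative activity, read by MTT assay, with stated times of 72 h and 4 h (a lower number here means a stronger inhibitor, a higher number a weaker inhibitor), can report. In this assay compound 2 gives > 100000 nM, which is a limit of the assay and not a number. Going by the values given here, compound 1 `O=C(Nc1ccc(Cl)c(-c2nnc3c(Cl)cccn23)c1)c1ccc(Cl)cc1Cl` is the only other compound measured. In this assay compound 1 likewise gives > 100000 nM, again a limit. Among the compounds with values here, the single measured step, a step that the two limits leave unreadable from compound 1 to compound 2, therefore has no readable size; what both values share is the limit of > 100000 nM in this assay, at which 2 of the 2 values shown sit. Compound 3 `O=C(Nc1ccc(Cl)c(-c2nnc3c(Cl)cccn23)c1)c1ccccc1Cl` differs from compound 2 by hydrogen in place of fluoro on an aromatic carbon, ortho to a large group and meta to a chloro group. Because the step that the two limits leave unreadable from compound 1 to compound 2 was left unreadable by two limits, the step of a number no higher from compound 2 to compound 3 (the limit leaves the size open) is expected to be none beyond the scatter. Compound 3 is estimated at 100000 nM, within a range from 20000 nM to 300000 nM, most likely reported as a limit again.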

Compound 3, half-maximal inhibitory concentration: 59900 nM
Beside the measured number, compound 3's estimate is 1.7-fold (0.22 log units) above it; measured number inside the range.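

Going by these compounds alone, with hydrogen in place of fluoro on an aromatic carbon, ortho to a large group and meta to a chloro group, compound 3 is the only one of the three compounds to give a number rather than a limit in this assay: 59900 nM. This yields an at least 1.6-fold lower number from compound 2 to compound 3 (0.22 log units; that floor lies within the scatter), and it yields an at least 1.6-fold lower number from compound 1 to compound 3 (0.22 log units; that floor lies within the scatter). The full size of these two steps stays open and the step between compound 1 and compound 2 still cannot be read, because the other two values are limits: the limit of > 100000 nM in this assay, at which 2 of the 3 values shown sit.

The compounds shown leave open what an amine or a carboxylic acid at the place of this hydrogen would give in this assay. Also open, as far as these compounds go, is what a methyl or a methoxy group in place of the remaining chloro of the 2-chlorophenyl would do to this number.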